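Trimming a Methoxy Group from an Inactive Analogue

This account rests on a few compounds, and the source may have more. Where it says the series, first, only, none or still open, it means among the compounds named here.

Compound 3 `COc1cc(OC)c2c(=O)cc(/C=C/c3ccc(OC(F)(F)F)cc3)oc2c1` carries two methoxy groups on the shared core and a trifluoromethoxy group on the other aromatic ring. In a functional assay on PC-3 cells (Homo sapiens) for antiproliferative activity, read by MTT assay, with a stated time of 12 h (a lower number here means a stronger inhibitor, a higher number a weaker inhibitor), compound 3 gives only a limit, > 40000 nM, not a measured number. Its closest relative, compound 2 `COc1cc(OC)c2c(=O)cc(/C=C/c3ccc(C(F)(F)F)cc3)oc2c1`, carries trifluoromethyl where compound 3 carries trifluoromethoxy. In this assay compound 2 likewise gives only a limit, > 40000 nM. The step that the two limits leave unreadable from compound 2 to compound 3 cannot be read because the limit of > 40000 nM in this assay, at which 2 of the 3 values shown sit, hides any difference between the two. Among the measured compounds shown here, the one compound with a real number is compound 1 `O=c1cc(/C=C/c2ccc(OC(F)(F)F)cc2)oc2ccccc12`, which has no methoxy group at all and gives 28900 nM in this assay. Compound 4 `COc1cccc2oc(/C=C/c3ccc(OC(F)(F)F)cc3)cc(=O)c12` keeps a single methoxy group. The change from compound 3 to compound 4 is hydrogen in place of methoxy on an aromatic carbon. For the measured compounds named here, no measured step shares this change, so the expectation rests on compound 1 alone, whose value 28900 nM is the only number among the three. A step of a number no higher from compound 3 to compound 4 (the limit leaves the size open) is expected in this assay. Compound 4 is estimated at 40000 nM, within a range from 15000 nM to 120000 nM.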

Compound 4, half-maximal inhibitory concentration: > 40000 nM
Compound 4: only a limit was reported; the forecaster's own chance of this, stated with the estimate: 55%; the middle value lies on the limit itself.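

Removing one methoxy group does not bring the compound into measurable range: in this assay, like compound 3, compound 4 gives only a limit, > 40000 nM. The step from compound 3 to compound 4 therefore cannot be read, and neither can any other step between these limit values, because none of them has a number to compare: the limit of > 40000 nM in this assay, at which 3 of the 4 values shown sit. The new information comes from compound 1, which has hydrogen where compound 4 has methoxy on an aromatic carbon, and this change gives an at least 1.3-fold higher number from compound 1 to compound 4 (0.14 log units; that floor lies within the scatter).

From the compounds shown here alone, how far the true values of compound 3 and compound 4 lie from the limit stays open, and with it the real size of the methoxy effect. Going by these compounds, what an amine or a carboxylic acid on this aromatic carbon would do also stays open.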